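The source may report more compounds than this note shows. Statements on the series, on what has been measured and on what is new or still open speak of the compounds shown alone.

In an ADME assay on HEK293 cells (Homo sapiens) for cytotoxicity, read by MTT assay, with a stated time of 48 h (on this read-out higher numbers stand for weaker inhibition and lower numbers for stronger inhibition), three compounds with a shared core have been measured so far. Compound 1 (`O=C([C@H]1CCCN1S(=O)(=O)c1ccccc1)N1CCN(c2ccnc3cc(Cl)ccc23)CC1`) reads 64100 nM and compound 2 (`COc1ccc(S(=O)(=O)N2CCC[C@@H]2C(=O)N2CCN(c3ccnc4cc(Cl)ccc34)CC2)cc1`) reads 57700 nM while compound 3 (`CC(C)(C)c1ccc(S(=O)(=O)N2CCC[C@@H]2C(=O)N2CCN(c3ccnc4cc(Cl)ccc34)CC2)cc1`) reads 53100 nM on the same scale. Compound 3 therefore sits level with the other two, inside the usual scatter of repeated measurements. Compound 4 (`O=C([C@H]1CCCN1S(=O)(=O)c1ccc(Cl)cc1)N1CCN(c2ccnc3cc(Cl)ccc23)CC1`) differs from compound 3 in one place, with chloro in place of tert-butyl on an aromatic carbon. Within the data shown here, three measured steps bear on this change. Methoxy in place of hydrogen gave a 1.1-fold lower number from compound 1 to compound 2 (0.05 log units; within the scatter) and tert-butyl in place of hydrogen gave a 1.2-fold lower number from compound 1 to compound 3 (0.08 log units; within the scatter) while tert-butyl in place of methoxy gave a 1.1-fold lower number from compound 2 to compound 3 (0.04 log units; within the scatter) and all three lie within the scatter. Chloro itself has not been measured at this place, so the evidence is indirect, but no change beyond the scatter is expected in this assay here. The expected step is a 1.1-fold higher number from compound 3 to compound 4 (0.02 log units; within the scatter) and it stays within the scatter. Compound 4 is estimated at 56000 nM with an expected range from 36000 nM to 85000 nM in this test.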

Compound 4, half-maximal inhibitory concentration: 46000 nM
For compound 4 the middle estimate is 1.2-fold (0.09 log units) above the measured one; low and high end bracket the measured number.
By their numbers in this assay, from the lowest: compounds 4, 3, 2 and 1 (each within the scatter of the next).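

In this assay, chloro on the aromatic carbon para to a large group also stays within the scatter of every earlier compound: a 1.2-fold lower number from compound 3 to compound 4 (0.06 log units; within the scatter), a 1.3-fold lower number from compound 2 to compound 4 (0.10 log units; within the scatter) and a 1.4-fold lower number from compound 1 to compound 4 (0.14 log units; within the scatter). Replacing tert-butyl, with its four carbons, by a single chlorine atom therefore gives no readable change, so a halogen joins hydrogen, methoxy and tert-butyl as groups that cannot be told apart at this place in this test. No evidence is available on why the readings stay level.

On these data alone, whether a group of another kind at this place, such as an amine or a carboxylic acid, would move the number beyond the scatter remains open. As far as these compounds go, all four compounds vary at this one place only, so the effect of changes elsewhere on the shared core also remains open.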